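Chalcone series on a shared pyridyl-amide ether core

The source may report more compounds than this note shows. Statements on the series, on what has been measured and on what is new or still open speak of the compounds shown alone.

Measured compounds:
- compound 1 `CNC(=O)c1cc(Oc2ccc(/C=C/C(=O)c3ccc([N+](=O)[O-])cc3)cc2)ccn1` — in a functional assay on PC-3 cells (Homo sapiens) for cytotoxicity, read by MTT assay, with a stated time of 72 h (a higher number here means a weaker inhibitor, a lower number a stronger inhibitor), compound 1 gives "not determined" (no result reported)
- compound 2 `CNC(=O)c1cc(Oc2ccc(C(=O)/C=C/c3cccc([N+](=O)[O-])c3)cc2)ccn1` — in this assay compound 2 gives "not determined" (no result reported)
- compound 3 `CNC(=O)c1cc(Oc2ccc(C(=O)/C=C/c3ccc(C#N)cc3)cc2)ccn1` — in this assay compound 3 gives 3870 nM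

Compound 2 stands without a number in this assay, and compound 1 also carries no number, so the only measured anchor for the series is compound 3. For the measured compounds named here, compound 2 and compound 3 share the same core and the same enone linkage and differ only in the ring substituent, nitro against nitrile, but no step between them has been reported, so no number can be attached to that comparison.

Compound 4 `CNC(=O)c1cc(Oc2ccc(C(=O)/C=C/c3ccccc3)cc2)ccn1` is the unsubstituted counterpart of compound 2. The change from compound 2 to compound 4 is hydrogen in place of nitro on an aromatic carbon. Going by the values given here, no measured step in this assay covers this change, so no direction is known from the data themselves; the expectation is a step of no more than the usual scatter, or a modest loss, since the one measured member, compound 3, sits at 3870 nM and carries a group of similar character.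

For compound 4 the estimated value in this assay is 4500 nM, with an expected range from 1500 nM to 14000 nM.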

Compound 4, half-maximal inhibitory concentration: 3170 nM
For compound 4 the middle estimate is 1.4-fold (0.15 log units) above the measured one, and the stated range covers the measured number.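

Taking the nitrile off the ring gives a 1.2-fold lower number from compound 3 to compound 4 (0.09 log units; within the scatter) in this assay, the first readable step in the series, so at this ring position a nitrile and a bare hydrogen cannot be told apart in this read-out. The step from compound 2 to compound 4 cannot be read, so the nitro-to-hydrogen change itself remains without a size. No supporting data bear on this result.

What the compounds shown leave open is whether any group on this ring moves the number beyond the scatter, for instance an amine, a carboxylic acid or a methoxy group. Also open, going by these compounds, is whether the flat result from nitrile to hydrogen holds for groups larger than a nitrile, such as a longer alkyl chain.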